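Series notes: the linker change from compound 3 to compound 4

This account rests on a few compounds, and the source may have more. Where it says the series, first, only, none or still open, it means among the compounds named here.

Compound 1 `O=C(COCc1cncs1)N1CCN(c2ccc(Cl)cc2Cl)CC1` gives 1280 nM in a functional assay on HEK293 cells for positive allosteric modulation of metabotropic glutamate receptor 5 (Homo sapiens), read by FLIPR and calcium flux; on this read-out lower numbers stand for an effect already at smaller amounts and higher numbers for an effect only at larger amounts of compound. Compound 2 `O=C(COCc1nccs1)N1CCN(c2ccc(Cl)cc2Cl)CC1` gives 10300 nM in this assay, and compound 3 `O=C(CNCc1ccncc1)N1CCN(c2ccc(Cl)cc2Cl)CC1` gives 8500 nM. Compound 3 therefore stands second highest of the three numbers; its gap to compound 2 lies within the scatter, whereas a 6.6-fold higher number from compound 1 to compound 3 (0.82 log units; beyond the scatter).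

Compound 4 `O=C(CSCc1ccccc1)N1CCN(c2ccc(Cl)cc2Cl)CC1` carries benzylsulfanyl in place of ((pyridin-4-yl)methyl)amino on a saturated chain carbon bound to a carbonyl carbon. Two measured steps touch the same place on the chain: the step from compound 1 to compound 3, described above, and a 1.2-fold lower number from compound 2 to compound 3 (0.08 log units; within the scatter). Changes at this position have so far ranged from nothing beyond the scatter to a modest rise. Among the compounds with values here, no measured pair puts a sulfur in the linker or removes the ring nitrogen, so the direction of the new step is not fixed by the data. Compound 4 is expected to give a somewhat lower number than compound 3, a 2.1-fold lower number from compound 3 to compound 4 (0.33 log units; beyond the scatter), with the step remaining near the scatter. The estimate for compound 4 in this assay is 4000 nM, within a range from 800 nM to 20000 nM.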

Compound 4, half-maximal effective concentration: 7100 nM
Estimate against measurement, compound 4: 1.8-fold (0.25 log units) below, within the range that was stated.
By their numbers in this assay, from the lowest: compound 1; then compounds 4, 3 and 2 (each within the scatter of the next).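

In this assay, benzylsulfanyl on a saturated chain carbon bound to a carbonyl carbon is the only group shown with a sulfur and a ring of carbon only, yet it gives no separation from ((pyridin-4-yl)methyl)amino (a 1.2-fold lower number from compound 3 to compound 4 (0.08 log units; within the scatter)) or from (1,3-thiazol-2-yl)methoxy (a 1.5-fold lower number from compound 2 to compound 4 (0.16 log units; within the scatter)). Only (1,3-thiazol-5-yl)methoxy stands apart (a 5.5-fold higher number from compound 1 to compound 4 (0.74 log units; beyond the scatter)), so compound 1 is now separated from all three others by more than the scatter. No available data bear on what lies behind these steps.

Going by these compounds, compounds 3 and 4 differ in both the chain atom and the ring, so the part played by each remains open. Also open, on these data alone, is how benzyloxy, (1,3-thiazol-5-yl)methylsulfanyl or a longer chain would compare with compound 1 at this position.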